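The source may report more compounds than this note shows. Statements on the series, on what has been measured and on what is new or still open speak of the compounds shown alone.

Measured so far in a functional assay on SK-OV-3 cells (Homo sapiens); on this read-out higher numbers stand for weaker inhibition of growth and lower numbers for stronger inhibition of growth:
- compound 1 `O=S(=O)(/C=C/c1ccc(C(F)(F)F)cc1F)Cc1ccc(Nc2ncnc3ccccc23)cc1`: 39000 nM
- compound 2 `O=S(=O)(/C=C/c1ccc(C(F)(F)F)cc1F)Cc1ccc(Nc2ncnc3ccc(Br)cc23)cc1`: 5000 nM
- compound 3 `O=S(=O)(/C=C/c1ccc(Cl)cc1Cl)Cc1ccc(Nc2ncnc3cc(Cl)ccc23)cc1`: 48000 nM

Compound 3 lies within the scatter of compound 1 and above compound 2, which gives 5000 nM. Compound 4 `O=S(=O)(/C=C/c1ccc(C(F)(F)F)cc1F)Cc1ccc(Nc2ncnc3cc(Cl)ccc23)cc1` differs from compound 3 by one change: 2-fluoro-4-(trifluoromethyl)phenyl in place of 2,4-dichlorophenyl on a double-bonded chain carbon bound to a double-bonded chain carbon, with 2-fluoro-4-(trifluoromethyl)phenyl in place of 2,4-dichlorophenyl. Among the compounds with values here, no measured step covers this swap. Within the data shown here, the only step, a 7.8-fold lower number from compound 1 to compound 2 (0.89 log units; beyond the scatter), is a bromo in place of hydrogen on an aromatic carbon, so it bears only indirectly. Compound 1, at 39000 nM, carries the entering group but also differs elsewhere from compound 3. In this assay, no step beyond the scatter is therefore expected. The expected step is a 1.4-fold lower number from compound 3 to compound 4 (0.14 log units; within the scatter). For compound 4 the estimate is 35000 nM, with an expected range of 13000 nM to 80000 nM.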

Compound 4, concentration for 50% growth inhibition: > 100000 nM
Compound 4: only a limit was reported (the forecaster's own chance of this, stated with the estimate: 10%); at least 2.8-fold (0.45 log units) between middle value and limit.
By their numbers in this assay, from the lowest: compound 2; then compounds 1 and 3 (each within the scatter of the next). At a limit, above all of these: compound 4.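

Compound 4 is reported in this assay only as a limit, not as a number: the limit of > 100000 nM in this assay, at which 1 of the 4 values shown sits. At the double-bonded chain carbon, 2-fluoro-4-(trifluoromethyl)phenyl in place of 2,4-dichlorophenyl gives an at least 2.0-fold higher number from compound 3 to compound 4 (0.31 log units; beyond the scatter), so this swap is not neutral here. On the core, chloro in place of hydrogen gives an at least 2.5-fold higher number from compound 1 to compound 4 (0.40 log units; beyond the scatter), opposite in direction to the bromo step, and exchanging the bromine-bearing group for the chlorine-bearing one gives an at least 20-fold higher number from compound 2 to compound 4 (1.30 log units; beyond the scatter). On these data alone, how far compound 4 lies past its limit stays open. So does how an amine or a carboxylic acid in place of the chloro would read in this assay.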